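Sulfonyl aryl trimming in the aminopyrimidine series

The source may report more compounds than this note shows. Statements on the series, on what has been measured and on what is new or still open speak of the compounds shown alone.

Compound 3 `Cc1ccc(S(=O)(=O)NCCCNc2nccc(-c3c(-c4cccc(F)c4)nc4sccn34)n2)cc1` gives 8380 nM in a functional assay on A-375 cells (Homo sapiens) for cytotoxicity, read by MTT assay (a lower number here means a stronger inhibitor, a higher number a weaker inhibitor), the second highest of the three numbers in hand. Compound 1 `O=S(=O)(NCCCNc1nccc(-c2c(-c3cccc(F)c3)nc3sccn23)n1)c1cccc(F)c1` gives 13700 nM in this assay, and the step of a 1.6-fold lower number from compound 1 to compound 3 (0.21 log units; within the scatter) stays within the scatter. Compound 2 `O=C(NCCNc1nccc(-c2c(-c3cccc(F)c3)nc3sccn23)n1)c1c(F)cccc1F` gives 2700 nM; the steps of a 5.1-fold lower number from compound 1 to compound 2 (0.71 log units; beyond the scatter) and a 3.1-fold higher number from compound 2 to compound 3 (0.49 log units; beyond the scatter) exchange the whole sulfonamide for an amide and do not bear on the present change. Compound 4 `O=S(=O)(NCCCNc1nccc(-c2c(-c3cccc(F)c3)nc3sccn23)n1)c1ccccc1` differs from compound 3 by hydrogen in place of methyl on an aromatic carbon. Among the compounds with values here, the one step that does bear on it, a 1.6-fold lower number from compound 1 to compound 3 (0.21 log units; within the scatter), also swapped the aryl group on the sulfonyl sulfur and stayed within the scatter. A step of no more than that size is therefore expected on going to compound 4 , a 1.1-fold higher number from compound 3 to compound 4 (0.05 log units; within the scatter), with no clear direction. Compound 4 is estimated at 9500 nM, expected between 4500 nM and 20000 nM.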

Compound 4, half-maximal inhibitory concentration: 6600 nM
Beside the measured number, compound 4's estimate is 1.4-fold (0.16 log units) above it; the measured number falls inside the stated range.
By their numbers in this assay, from the lowest: compound 2; then compounds 4, 3 and 1 (each within the scatter of the next, the first and the last beyond it).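

Notes on the sulfonyl aryl group: in this assay, the step of a 1.3-fold lower number from compound 3 to compound 4 (0.10 log units; within the scatter) shows that the methyl para to a large group can go without a readable change. Hydrogen in place of fluoro does register, with a 2.1-fold lower number from compound 1 to compound 4 (0.32 log units; beyond the scatter), so the two aryl replacements do not read alike. Compound 4 still stays apart from the amide, with a 2.4-fold higher number from compound 2 to compound 4 (0.39 log units; beyond the scatter), so the phenylsulfonyl group does not close that gap.

Nothing available accounts for these steps. From the compounds shown here alone, whether a methoxy group or a chlorine at the same para position would move the number remains open.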